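Permeability notes on a diacid indole series

The source may hold more compounds than are shown below. What is called first, only, known or untested is meant among the compounds shown, and "the series" means these compounds.

Two compounds in the series have been run in a physicochemical assay for permeability, using PAMPA, with a stated time of 4 h, at pH 7.4, tested at 50 uM; a higher number here means that the compound crosses the layer faster, a lower number that the compound crosses the layer more slowly. Compound 1 `Cc1c(Cl)cccc1CCCCOc1ccc(C#Cc2cccc3c(CC(=O)O)c(C)n(CCCCC(=O)O)c23)cc1`, carrying an acetic acid on the core and a pentanoic acid on the nitrogen, gives 1 10^-6 cm/s in this assay. Compound 2 `Cc1c(CCCC(=O)O)c2cccc(/C=C/c3ccc(OCCCCc4ccccc4)cc3)c2n1CC(=O)O`, which places a butanoic acid on the core and an acetic acid on the nitrogen, returns only a limit in this assay, < 0.05 10^-6 cm/s, and so no number stands for it. The evidence in hand is thin: the limit of < 0.05 10^-6 cm/s in this assay, at which 1 of the 2 values shown sits.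

Compound 3 `Cc1c(CCCC(=O)O)c2cccc(/C=C/c3ccc(OCCCCc4c(F)cc(F)c(F)c4F)cc3)c2n1CC(=O)O` is the next member to be measured. It differs from compound 2 in one place: 2,3,4,6-tetrafluorophenyl in place of phenyl on a saturated chain carbon, four bonds along the chain from an oxygen on an aromatic ring.

For the measured compounds named here, with no measured pair showing what this change does, there is no basis for expecting a step beyond the usual scatter in either direction, and the value of compound 3 in this assay is estimated to stay near the floor, with the step of an at least 1.2-fold higher number from compound 2 to compound 3 (0.07 log units; that floor lies within the scatter) counted as none beyond the scatter. Compound 3 is therefore expected to read about 0.06 10^-6 cm/s, within 0.02 10^-6 cm/s to 0.25 10^-6 cm/s, with a fair chance that only a limit is reported.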

Compound 3, apparent permeability: 0.3 10^-6 cm/s
For compound 3 the middle estimate is 5.0-fold (0.70 log units) below the measured one; measured number above the stated range.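

In this assay, 2,3,4,6-tetrafluorophenyl in place of phenyl on a saturated chain carbon, four bonds along the chain from an oxygen on an aromatic ring, gives an at least 6.0-fold higher number from compound 2 to compound 3 (0.77 log units; beyond the scatter), so this series now has a measured pair showing that a change at this position can move the read-out beyond the scatter. With this change, the series with a butanoic acid on the core and an acetic acid on the nitrogen has a member with a number rather than only a limit. Compound 2 stands at a limit and not a number, so the step fixes only a lower bound on the size of the change: the limit of < 0.05 10^-6 cm/s in this assay, at which 1 of the 3 values shown sits.

The compounds shown do not tell whether all four fluorines are needed for this step, or whether a single fluorine, a pyridine ring or an amine in the same place would give a similar one. From the compounds shown here alone, compound 1 differs from compound 3 in more than one place, so how the alkyne and the placement of the two acids bear on this change remains open.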